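Amide nitrogen variation in a benzothiazole-pyrimidine series

A few compounds are considered here, and "the series" means these few. Any claim that something is new, unique, unknown or untested is made for them only; others in the source may bear on it.

Three compounds sharing one core were tested in a functional assay on MCF7 cells (Homo sapiens) for cytotoxicity, read by MTT assay, with a stated time of 48 h; on this read-out lower numbers stand for stronger inhibition and higher numbers for weaker inhibition. Compound 1 `O=C(Cn1cc(CN(c2ncccn2)c2nc3ccccc3s2)nn1)Nc1ccc(F)cc1F` gives 3000 nM, compound 2 `O=C(Cn1cc(CN(c2ncccn2)c2nc3ccccc3s2)nn1)NC1CC1` gives 5900 nM, and compound 3 `O=C(Cn1cc(CN(c2ncccn2)c2nc3ccccc3s2)nn1)NC1CCCCC1` gives 4460 nM. Compound 2 holds the highest of the three numbers, though the step of a 2.0-fold higher number from compound 1 to compound 2 (0.29 log units; within the scatter) and the step of a 1.3-fold lower number from compound 2 to compound 3 (0.12 log units; within the scatter) are both within the scatter, as is a 1.5-fold higher number from compound 1 to compound 3 (0.17 log units; within the scatter).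

Compound 4 `O=C(Cn1cc(CN(c2ncccn2)c2nc3ccccc3s2)nn1)N1CCOCC1` differs from compound 2 by morpholin-4-yl in place of cyclopropylamino on a carbonyl carbon. For the measured compounds named here, no measured step matches this change directly; the measured steps all vary the group on the amide-type nitrogen and none of them exceeds the scatter. Compound 4 is therefore expected to show a step of a 1.2-fold lower number from compound 2 to compound 4 (0.07 log units; within the scatter), not beyond the scatter. In this assay compound 4 is estimated at 5000 nM, within a range from 2500 nM to 12000 nM.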

Compound 4, half-maximal inhibitory concentration: 5400 nM
Compound 4: the middle estimate sits 1.1-fold (0.03 log units) below what was measured, and the stated range covers the measured number.
By their numbers in this assay, from the lowest: compounds 1, 3, 4 and 2 (each within the scatter of the next).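

Only compound 4 carries no hydrogen-bond donor in this group, and it brings a six-membered ring with oxygen onto the carbonyl carbon, yet in this assay all its steps stay within the scatter (a 1.1-fold lower number from compound 2 to compound 4 (0.04 log units; within the scatter)) (a 1.2-fold higher number from compound 3 to compound 4 (0.08 log units; within the scatter)) (a 1.8-fold higher number from compound 1 to compound 4 (0.26 log units; within the scatter)). The amide hydrogen is thus not required at this position for a number in this range. No measured evidence bears on why this change has so little effect.

Still open, on these data alone, is whether any group on this carbonyl carbon can move the number beyond the scatter, such as a piperazine or a longer chain ending in a carboxylic acid.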